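The compounds below may be only part of what the source reports. "The series", "measured", "known", "first", "only" and "open" are said of these compounds alone.

Compound 1 `NCc1cc(Oc2cccc(C(=O)NCCS(N)(=O)=O)c2)nc(C(F)(F)F)c1`: 1040 nM. Compound 2 `NCc1cc(Oc2cccc(C(=O)NCc3cc4ccccc4s3)c2)nc(C(F)(F)F)c1`: "not determined" (no result reported).

In an ADME assay on the whole organism (plasma, Mus musculus) for pharmacokinetics, read by LC-MS, at a dose of 30 mg/kg by the oral route (a higher number here means more compound in the circulation at the dose given, a lower number less compound in the circulation), compound 1 gives 1040 nM. For compound 2 the read-out in this assay is "not determined" (no result reported), so there is no number to say where compound 2 stands. Compound 3 `NCc1cc(Oc2cccc(C(=O)NCCn3cnnn3)c2)nc(C(F)(F)F)c1` differs from compound 2 by (1H-tetrazol-1-yl)methyl in place of 1-benzothiophen-2-yl on a saturated chain carbon bound to an amide-type nitrogen. Within the data shown here, no measured pair shows this change, so neither its size nor its direction in this assay can be read from the data, and a step in either direction beyond the scatter is possible. Leaning on compound 1, which gave 1040 nM, compound 3 is estimated to reach about 800 nM, expected between 200 nM and 3200 nM.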

Compound 3, maximal plasma concentration: 1990 nM
Beside the measured number, compound 3's estimate is 2.5-fold (0.40 log units) below it; measured number inside the range.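

In this assay, 1H-tetrazol-1-yl in place of sulfamoyl on a saturated chain carbon, two bonds along the chain from an amide-type nitrogen, gives a 1.9-fold higher number from compound 1 to compound 3 (0.28 log units; within the scatter). Among these compounds, this is the first readable comparison at this position, and in this read-out the two end groups cannot be told apart. Nothing at hand explains the result.

With no number for compound 2, its steps to the other two compounds cannot be read. A carboxylic acid or an amine at the end of this chain, or a longer chain, remains an open question.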